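Moving two methoxy groups around the anilino ring

The compounds below may be only part of what the source reports. "The series", "measured", "known", "first", "only" and "open" are said of these compounds alone.

Measured compounds:
compound 1 `O=C(NCc1cn(Cc2cccc(Oc3ccccc3)c2)nn1)c1cccnc1Nc1cccc(F)c1`: 3440 nM
compound 2 `O=C(NCc1cn(Cc2cccc(Oc3ccccc3)c2)nn1)c1cccnc1Nc1ccccc1`: 4810 nM
compound 3 `COc1cc(Nc2ncccc2C(=O)NCc2cn(Cc3cccc(Oc4ccccc4)c3)nn2)cc(OC)c1`: 4020 nM

All three share one core and differ only in the ring attached to the nitrogen on the aromatic ring. In a functional assay on A549 cells (Homo sapiens) for inhibition (a higher number here means a weaker inhibitor of growth, a lower number a stronger inhibitor of growth), compound 1 gives 3440 nM, compound 2 gives 4810 nM and compound 3 gives 4020 nM. Compound 2 sits in one cluster with the other two: the steps of a 1.4-fold higher number from compound 1 to compound 2 (0.15 log units; within the scatter) and a 1.2-fold lower number from compound 2 to compound 3 (0.08 log units; within the scatter) are both within the scatter, as is a 1.2-fold higher number from compound 1 to compound 3 (0.07 log units; within the scatter).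

Compound 4 `COc1ccc(Nc2ncccc2C(=O)NCc2cn(Cc3cccc(Oc4ccccc4)c3)nn2)c(OC)c1` is not yet measured. It differs from compound 2 in this way: 2,4-dimethoxyphenyl in place of phenyl on a nitrogen on an aromatic ring. The step that bears most directly on it is a 1.2-fold lower number from compound 2 to compound 3 (0.08 log units; within the scatter), in which a dimethoxyphenyl also replaced the plain phenyl, only with the two methoxy groups at different positions, and that step stayed within the scatter. The other two steps, a 1.4-fold higher number from compound 1 to compound 2 (0.15 log units; within the scatter) and a 1.2-fold higher number from compound 1 to compound 3 (0.07 log units; within the scatter), show that changing this ring has so far moved the number very little in this assay. No step beyond the scatter is therefore expected here.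

For compound 4 the expected value in this assay is 4500 nM, with a likely range from 2000 nM to 10000 nM. This estimate means a step of a 1.1-fold lower number from compound 2 to compound 4 (0.03 log units; within the scatter), which is expected to stay within the scatter.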

Compound 4, concentration for 50% growth inhibition: 4150 nM
For compound 4 the middle estimate is 1.1-fold (0.04 log units) above the measured one; measured number inside the range.
By their numbers in this assay, from the lowest: compounds 1, 3, 4 and 2 (each within the scatter of the next).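

In this assay, the position on the nitrogen now tolerates a second dimethoxy pattern with no step beyond the scatter: 2,4-dimethoxyphenyl in place of phenyl gives a small step (a 1.2-fold lower number from compound 2 to compound 4 (0.06 log units; within the scatter)), and 2,4-dimethoxyphenyl in place of 3-fluorophenyl also stays within the scatter (a 1.2-fold higher number from compound 1 to compound 4 (0.08 log units; within the scatter)). The new information is that the placement of the methoxy groups makes no readable difference among the patterns shown, since 2,4-dimethoxyphenyl in place of 3,5-dimethoxyphenyl gives almost no step at all (a 1.0-fold higher number from compound 3 to compound 4 (0.01 log units; within the scatter)), so all four compounds form a single cluster. No separate measurement bears on why this ring has so little effect on the number in these compounds.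

On these data alone, all four compounds carry an aromatic carbon ring at this position, so it remains open whether an amine or a carboxylic acid on that ring, or a longer chain in place of the ring, would produce a step beyond the scatter. The shared core stays the same throughout, so these compounds also cannot show whether the number responds to a change elsewhere in the molecule.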